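Bromo Substitution Repeated on a Second Core

The compounds below may be only part of what the source reports. "The series", "measured", "known", "first", "only" and "open" are said of these compounds alone.

Compound 1 `O=C1N=C(N2N=C(c3ccccc3)CC2c2ccccc2O)S/C1=C1/C(=O)Nc2ccccc21`: 4400 nM
Compound 2 `O=C1N=C(N2N=C(c3ccccc3)CC2c2ccccc2O)S/C1=C1/C(=O)Nc2ccc(Br)cc21`: 660 nM
Compound 3 `COc1ccc(C2CC(c3ccc4ccccc4c3)=NN2C2=NC(=O)/C(=C3\C(=O)Nc4ccccc43)S2)cc1`: 27000 nM

All three were tested in a functional assay on cells (Melanoma cell, Homo sapiens) for cytotoxicity, read by sulforhodamine B assay, with a stated time of 48 h; a lower number here means a stronger inhibitor of growth, a higher number a weaker inhibitor of growth. Compound 1 and compound 2 share a core and differ by bromo in place of hydrogen on an aromatic carbon; this change gave a 6.7-fold lower number from compound 1 to compound 2 (0.82 log units; beyond the scatter). Compound 3 gives the highest number of the three in this assay; how its core differs from that of compound 1 is not broken down here.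

Compound 4 `COc1ccc(C2CC(c3ccc4ccccc4c3)=NN2C2=NC(=O)/C(=C3\C(=O)Nc4ccc(Br)cc43)S2)cc1` is unmeasured. It differs from compound 3 by bromo in place of hydrogen on an aromatic carbon, the same change as that between compound 1 and compound 2, made at the same kind of place. The step from compound 3 to compound 4 is expected to be a 5.4-fold lower number from compound 3 to compound 4 (0.73 log units; beyond the scatter). This expectation rests on compound 1 and compound 2, whose step was a 6.7-fold lower number from compound 1 to compound 2 (0.82 log units; beyond the scatter), with some allowance for the different core. Compound 4 is therefore estimated at 5000 nM, between 1500 nM and 16000 nM.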

Compound 4, concentration for total growth inhibition: 190 nM
Compound 4: the middle estimate sits 26-fold (1.42 log units) above what was measured, outside the stated range (below it).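

In this assay, bromo in place of hydrogen on an aromatic carbon again gave a lower number, here a 140-fold lower number from compound 3 to compound 4 (2.15 log units; beyond the scatter). The direction of the change carried over from the core of compound 1 to the core of compound 3, but its size did not: the same change on two cores in this assay, a 6.7-fold lower number (0.82 log units; beyond the scatter) from compound 1 to compound 2 and a 140-fold lower number (2.15 log units; beyond the scatter) from compound 3 to compound 4, 21-fold (1.33 log units) apart, beyond the scatter of two such steps. Two cores cannot show which difference between them goes with the larger step, or what size the change would have on a third core.

The compounds shown leave open whether chloro or fluoro at this place would follow bromo in direction and size on both cores. They also leave open what an amine or a carboxylic acid there would do.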